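Replacing the Aryl Group in Compound 1: What to Expect

The source may report more compounds than this note shows. Statements on the series, on what has been measured and on what is new or still open speak of the compounds shown alone.

Measured so far:
Compound 1 `COc1cc(/C=C/c2ccc(NC(=O)/C=C/c3cc(OC)c(O)c(OC)c3)cc2)cc(OC)c1` gives 7130 nM in a functional assay on MDA-MB-231 cells (Homo sapiens) for inhibition, read by MTT assay, with a stated time of 48 h; a lower number here means a stronger inhibitor, a higher number a weaker inhibitor.
Compound 2 `COc1cc(/C=C/c2ccc(NC(=O)/C=C/c3ccc(Br)cc3)cc2)cc(OC)c1` gives 6160 nM in this assay.

Among these two numbers compound 1 holds the highest, and its nearest neighbour is compound 2, reached by a 1.2-fold lower number from compound 1 to compound 2 (0.06 log units; within the scatter); the two values therefore cannot be told apart.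

Compound 3 `COc1cc(/C=C/c2ccc(NC(=O)/C=C/c3ccc(O)c(O)c3)cc2)cc(OC)c1` has not been measured. It differs from compound 1 in one place: 3,4-dihydroxyphenyl in place of 4-hydroxy-3,5-dimethoxyphenyl on a double-bonded chain carbon bound to a double-bonded chain carbon. Going by the values given here, the only measured step that bears on this change is the one from compound 1 to compound 2, where the same 4-hydroxy-3,5-dimethoxyphenyl at the same place gave way to a different ring, and that step, a 1.2-fold lower number from compound 1 to compound 2 (0.06 log units; within the scatter), stayed within the scatter. Among the compounds with values here, no measured compound carries a 3,4-dihydroxyphenyl, so nothing further can be read from the data about this particular group.

Given that the one comparable replacement left the number essentially unchanged, the step to compound 3 is expected to be small, a 1.0-fold lower number from compound 1 to compound 3 (0.01 log units; within the scatter), with no clear direction. Compound 3 is estimated at 7000 nM in this assay, expected to fall between 2500 nM and 20000 nM.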

Compound 3, half-maximal inhibitory concentration: 4230 nM
The estimate for compound 3 lay 1.7-fold (0.22 log units) above the measured number, within the range that was stated.
By their numbers in this assay, from the lowest: compounds 3, 2 and 1 (each within the scatter of the next).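

In this assay a third ring on a double-bonded chain carbon bound to a double-bonded chain carbon again stays within the scatter, both for the step from the original ring (a 1.7-fold lower number from compound 1 to compound 3 (0.23 log units; within the scatter)) and for the step from the bromine-bearing ring (a 1.5-fold lower number from compound 2 to compound 3 (0.16 log units; within the scatter)). Until now a single replacement stood alone, but 4-hydroxy-3,5-dimethoxyphenyl, 4-bromophenyl and 3,4-dihydroxyphenyl now give three numbers that cannot be told apart, even though the change from compound 1 to compound 3 takes the group from 11 heavy atoms to 8 and from 1 hydrogen-bond donor to 2. No measurement shown here offers a reason for this sameness.

Going by these compounds, these three compounds cover only aromatic rings with hydroxy, methoxy or bromine substituents at this place, so it remains open whether a ring carrying an amine or a carboxylic acid, or a plain unsubstituted phenyl, would move the number beyond the scatter. Also open, on these data alone, is what a longer chain between the amide carbonyl and the ring would do, and whether changes elsewhere on the shared core matter more than this position.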